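This account rests on a few compounds, and the source may have more. Where it says the series, first, only, none or still open, it means among the compounds named here.

Among the measured compounds shown here, in a functional assay (aorta) with Oryctolagus cuniculus as the target (a lower number here means tighter binding, a higher number weaker binding), two compounds with the same core have numbers so far. Compound 1 (`COCc1nc2c(C)ccnc2n1Cc1ccc(-c2ccccc2C(=O)O)cc1`) gives 79.4 nM, and compound 2 (`C/C=C/c1nc2c(C)ccnc2n1Cc1ccc(-c2ccccc2C(=O)O)cc1`) gives 5.01 nM, the lower of the two and clearly separated from the other. The next compound is compound 3 (`CSc1nc2c(C)ccnc2n1Cc1ccc(-c2ccccc2C(=O)O)cc1`), which has methylsulfanyl in place of prop-1-en-1-yl on an aromatic carbon, the difference being (methylsulfanyl in place of prop-1-en-1-yl on an aromatic carbon). For the measured compounds named here, only one measured step bears on this change, a large one at the same carbon: a 16-fold lower number from compound 1 to compound 2 (1.20 log units; beyond the scatter), which brought in prop-1-en-1-yl. Compound 3 gives that group up, so a higher number is expected in this assay, though a single step cannot show where methylsulfanyl will rank. The expected change is a 5.0-fold higher number from compound 2 to compound 3 (0.70 log units; beyond the scatter). For compound 3 the estimated value is 25 nM, with an expected range of 6 nM to 100 nM.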

Compound 3, dissociation constant: 10 nM
Beside the measured number, compound 3's estimate is 2.5-fold (0.40 log units) above it, within the range that was stated.
By their numbers in this assay, from the lowest: compounds 2 and 3 (each within the scatter of the next); then compound 1.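

In this assay the carbon between two ring nitrogen atoms takes a second group with no separation from the first: a 2.0-fold higher number from compound 2 to compound 3 (0.30 log units; within the scatter) even though methylsulfanyl, with 2 heavy atoms and no double bond outside aromatic rings, replaces prop-1-en-1-yl, with 3 heavy atoms and 1 such double bond. The low numbers at this carbon are therefore not confined to prop-1-en-1-yl, and the change from methoxymethyl also holds for the sulfur-bearing group, with a 7.9-fold lower number from compound 1 to compound 3 (0.90 log units; beyond the scatter) on the shared core. Nothing available gives a reason for these numbers.

As far as these compounds go, how an amine, a carboxylic acid or a longer chain would read at this carbon stays open. From the compounds shown here alone, it is also open whether the same three groups would keep these relations on a different core.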